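Moving two chlorines around a dichlorophenyl group

This account rests on a few compounds, and the source may have more. Where it says the series, first, only, none or still open, it means among the compounds named here.

In an ADME assay on K562 cells (Homo sapiens) for cytotoxicity, read by MTT assay, with a stated time of 24 h (on this read-out higher numbers stand for lower toxicity in this test and lower numbers for higher toxicity in this test), compound 1 (`Clc1ccc(C(CCn2ccnc2)Oc2ccc(Cl)cc2Cl)cc1`) gives 68800 nM and compound 2 (`Clc1ccc(C(CCn2ccnc2)Oc2ccccc2Cl)cc1`) gives 205000 nM. Compound 3 (`Clc1ccc(C(CCn2ccnc2)Oc2c(Cl)cccc2Cl)cc1`) gives 135000 nM, which lies within the scatter of both, as a 2.0-fold higher number from compound 1 to compound 3 (0.29 log units; within the scatter) and a 1.5-fold lower number from compound 2 to compound 3 (0.18 log units; within the scatter) show. Only a 3.0-fold higher number from compound 1 to compound 2 (0.47 log units; beyond the scatter) clears the scatter, and that step removes a chloro group. Compound 4 (`Clc1ccc(C(CCn2ccnc2)Oc2cc(Cl)cc(Cl)c2)cc1`) has the same atoms as compound 3, joined differently: 3,5-dichlorophenyl in place of 2,6-dichlorophenyl on an oxygen on a saturated carbon. Among the compounds with values here, no chloro group is lost here, and the one measured exchange of dichlorophenyl groups, a 2.0-fold higher number from compound 1 to compound 3 (0.29 log units; within the scatter), stays within the scatter. The expected change is therefore small, a 1.4-fold lower number from compound 3 to compound 4 (0.15 log units; within the scatter), and no shift beyond the scatter is expected. For compound 4 the estimated value is 96000 nM, with an expected range of 50000 nM to 185000 nM.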

Compound 4, half-maximal cytotoxic concentration: 135000 nM
Compound 4: middle estimate off by 1.4-fold (0.15 log units), on the low side; the measured number falls inside the stated range.
By their numbers in this assay, from the lowest: compounds 1, 3, 4 and 2 (each within the scatter of the next, the first and the last beyond it).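

In this assay the exchange of 2,6-dichlorophenyl for 3,5-dichlorophenyl on the oxygen gives no change at the digits printed from compound 3 to compound 4 (within the scatter) and thus leaves the number where it stood. The other two steps, a 1.5-fold lower number from compound 2 to compound 4 (0.18 log units; within the scatter) and a 2.0-fold higher number from compound 1 to compound 4 (0.29 log units; within the scatter) in turn, also stay within the scatter, so a second exchange of dichlorophenyl groups clears it no more than the first did. No measurement shown offers a reason for this. The compounds shown leave open whether an amine or a carboxylic acid in place of a chloro group would move the number beyond the scatter.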